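Removing a Hydroxypyrrolidine from Compound 3

A few compounds are considered here, and "the series" means these few. Any claim that something is new, unique, unknown or untested is made for them only; others in the source may bear on it.

Three compounds have been measured in an assay on isolated protein for inhibition of serine/threonine-protein kinase D2 (Homo sapiens), read by mobility shift assay, tested at 30 uM; a lower number here means less inhibition, a higher number more inhibition at the concentration tested (going by the name of the read-out):
Compound 1, `COc1ccc(-c2cc3[nH]nc(N)c3c(=O)[nH]2)cc1`, gives 28%.
Compound 2, `Cc1cc2c(c(N)nn2C)c(=O)[nH]1`, gives 5%.
Compound 3, `Cc1cc2c(c(N)nn2C)c(N2CC[C@H](O)C2)n1`, gives 8%.

Among these three, compound 3 stands second highest. Its nearest neighbour is compound 2, whose number lies a little lower but within the usual scatter, so the two cannot be told apart. For the measured compounds named here, compound 1 lies clearly higher, beyond the scatter, and is the only compound here whose inhibition rises well above the others.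

Compound 4, `Cc1cc2c(cn1)c(N)nn2C`, has not yet been measured. It differs from compound 3 in one place: hydrogen in place of 3-hydroxypyrrolidin-1-yl on an aromatic carbon. The shared core and the methyl group stay as they are; only the five-membered ring with its hydroxyl is stripped away.

Going by the values given here, no pair of measured compounds that differ in exactly one place is available, so the size of this step must be judged from the general picture. Compound 2 and compound 3, which carry different groups at roughly the same region of the core, both sit at low inhibition, which suggests the core alone contributes little. Compound 4 is therefore expected to remain at a low inhibition number, with a step from compound 3 of about a number 3 percentage points lower from compound 3 to compound 4 (within the scatter), within the scatter. The estimate for compound 4 is 5%, expected to fall between -8% and 18%.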

Compound 4, a percentage reported as inhibition, at one concentration (the size of the read-out at that concentration, not a potency): -3%
Compound 4: the middle estimate sits 8 percentage points above what was measured, and the stated range covers the measured number.
By their numbers in this assay, from the lowest: compounds 4, 2 and 3 (each within the scatter of the next, the first and the last beyond it); then compound 1.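

In this assay, for the compounds shown here, replacing the 3-hydroxypyrrolidin-1-yl group on the aromatic carbon next to the ring nitrogen with hydrogen gives a number 11 percentage points lower from compound 3 to compound 4 (beyond the scatter), and this is the first step here that isolates a single change. It shows that this position is not silent: the number responds when the group leaves, even though the step is modest and compound 3 itself reaches only 8% in this test. No measurement at hand explains why the step occurs, so the result records a change in inhibition and nothing about its cause.

The compounds shown leave open whether the hydroxyl or the ring accounts for the step, a question that a plain pyrrolidin-1-yl group on the same carbon would help to separate, and whether an open-chain group such as dimethylamino would give a similar number. Also open, as far as these compounds go, is whether a longer chain ending in a carboxylic acid or a primary amine could lift inhibition further, as a single modest step cannot show how far this position can go.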